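From trifluoromethyl to fluoro at the assay limit

The compounds below may be only part of what the source reports. "The series", "measured", "known", "first", "only" and "open" are said of these compounds alone.

Values measured in a functional assay on OVCAR-8 cells (Homo sapiens); a lower number here means a stronger inhibitor of growth, a higher number a weaker inhibitor of growth:
- Compound 1 `O=S(=O)(/C=C/c1ccc(C(F)(F)F)cc1F)Cc1ccc(Nc2ncnc3ccc(Br)cc23)cc1` gives 15000 nM.
- Compound 2 `O=S(=O)(/C=C/c1ccc(Cl)cc1Cl)Cc1ccc(Nc2ncnc3cc(Cl)ccc23)cc1` gives > 100000 nM, which is a limit of the assay.
- Compound 3 `O=S(=O)(/C=C/c1ccc(C(F)(F)F)cc1F)Cc1ccc(Nc2ncnc3cc(Cl)ccc23)cc1` gives > 100000 nM, which is a limit of the assay.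

Compound 3 therefore stands without a number in this assay, and the same is true of compound 2. Taken together, the series shows (the limit of > 100000 nM in this assay, at which 2 of the 3 values shown sit).

Compound 4 `O=S(=O)(/C=C/c1ccc(F)cc1F)Cc1ccc(Nc2ncnc3cc(Cl)ccc23)cc1` differs from compound 3 only in its aryl group, where 2-fluoro-4-(trifluoromethyl)phenyl becomes 2,4-difluorophenyl. This places fluoro in place of trifluoromethyl on an aromatic carbon.

The measured change closest to this one, on the same group, gives a step that the two limits leave unreadable from compound 2 to compound 3, so it sets no size. The other measured change, on the core rather than the aryl group, gives an at least 6.6-fold higher number from compound 1 to compound 3 (0.82 log units; beyond the scatter). It lies beyond the scatter but does not bear directly on the new change.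

Compound 2 and compound 3 share the core of compound 4, and neither gives a number. No step beyond the scatter is therefore expected, and another limit is the likeliest report. The expected change is a number no higher from compound 3 to compound 4 (the limit leaves the size open). Compound 4 is estimated at 100000 nM, with an expected range from 30000 nM to 200000 nM.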

Compound 4, concentration for 50% growth inhibition: > 100000 nM
Compound 4: a limit, no number; the forecaster's own chance of this, stated with the estimate: 80%; the middle value lies on the limit itself.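

In this assay compound 4 gives > 100000 nM, which is a limit of the assay and not a number. Among these compounds, its steps from compound 2 and from compound 3 therefore cannot be read, so no new step emerges: the limit of > 100000 nM in this assay, at which 3 of the 4 values shown sit.

The compounds shown leave open whether the aryl groups of compound 2, compound 3 and compound 4 differ at all in this assay.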